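A few compounds are considered here, and "the series" means these few. Any claim that something is new, unique, unknown or untested is made for them only; others in the source may bear on it.

Three compounds share one core and differ only in the group on the aromatic nitrogen. In a functional assay (trachea) with Cavia porcellus as the target (on this read-out higher numbers stand for weaker inhibition and lower numbers for stronger inhibition), compound 1 `CC(C)=CCn1nc(-c2cccnc2)c2ccccc2c1=O` gives 1380 nM, compound 2 `O=c1c2ccccc2c(-c2cccnc2)nn1C1CCCC1` gives 2750 nM and compound 3 `O=c1c2ccccc2c(-c2cccnc2)nn1Cc1ccccc1` gives 2450 nM. Compound 3 stands within the scatter of both other compounds: the data show a 1.1-fold lower number from compound 2 to compound 3 (0.05 log units; within the scatter) and a 1.8-fold higher number from compound 1 to compound 3 (0.25 log units; within the scatter).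

Compound 4 `O=c1c2ccccc2c(-c2cccnc2)nn1Cc1cccc(Cl)c1` keeps the benzyl group of compound 3 and carries one change: chloro in place of hydrogen on an aromatic carbon. This is chloro in place of hydrogen on an aromatic carbon, meta to a large group, so benzyl becomes 3-chlorobenzyl.

Within the data shown here, no measured step tests a substituent on that aromatic ring, so the evidence is only indirect. The nearest steps are exchanges of the whole group on the nitrogen, including a 2.0-fold higher number from compound 1 to compound 2 (0.30 log units; within the scatter). Like the two steps to compound 3, this one stays within the scatter, but none of the three says anything specific about chloro. In this assay, no step beyond the scatter is therefore expected, and the data support no firm direction. The expected step is a 1.2-fold lower number from compound 3 to compound 4 (0.09 log units; within the scatter). The estimate for compound 4 is 2000 nM, with an expected range from 800 nM to 5000 nM.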

Compound 4, half-maximal inhibitory concentration: 4170 nM
Compound 4: the middle estimate sits 2.1-fold (0.32 log units) below what was measured, and the stated range covers the measured number.
By their numbers in this assay, from the lowest: compounds 1, 3, 2 and 4 (each within the scatter of the next, the first and the last beyond it).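

Chloro on this aromatic carbon of the benzyl group gives a 1.7-fold higher number from compound 3 to compound 4 (0.23 log units; within the scatter) in this assay, so the first substituent seen on that ring cannot be told apart from compound 3, and the change to 3-chlorobenzyl leaves the result in the same range as the earlier groups on the nitrogen, with a 1.5-fold higher number from compound 2 to compound 4 (0.18 log units; within the scatter) as well. Among these compounds, the only step beyond the scatter so far is modest, a 3.0-fold higher number from compound 1 to compound 4 (0.48 log units; beyond the scatter), yet compound 3 lies within the scatter of both compound 1 and compound 4, so this gap cannot be assigned to chloro alone. Nothing available bears on why these numbers fall as they do.

As far as these compounds go, what remains open is whether any substituent on this ring can move the number beyond the scatter in either direction, for instance methoxy, a nitrile, an amine or a carboxylic acid on the same aromatic carbon. Also open, from the compounds shown here alone, is whether chloro on another carbon of the ring would read the same, and whether a longer chain between the nitrogen and the phenyl ring would differ from benzyl.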